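The source may hold more compounds than are shown below. What is called first, only, known or untested is meant among the compounds shown, and "the series" means these compounds.

Compound 1 `Cc1cc(-c2nc3sc(C)cn3c2/C=N/NC(=N)N)c(C)s1` is the starting point of this set. In a functional assay on cells (Cancer cell lines, Homo sapiens) for inhibition (a higher number here means a weaker inhibitor of growth, a lower number a stronger inhibitor of growth), compound 1 gives 4790 nM. Compound 2 `Cc1cn2c(/C=N/NC(=N)N)c(-c3cccs3)nc2s1` differs from it by one change, (thiophen-2-yl in place of 2,5-dimethylthiophen-3-yl on an aromatic carbon), and in this assay compound 2 gives 3020 nM. The step of a 1.6-fold lower number from compound 1 to compound 2 (0.20 log units; within the scatter) is therefore small.

Compound 3 `Cc1cc(-c2nc3n(c2/C=N/NC(=N)N)CCS3)c(C)s1` rests on a different core; how its core differs from that of compound 1 is not broken down here. In this assay compound 3 gives 15500 nM, the highest number of the three measured compounds.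

Compound 4 `N=C(N)N/N=C/c1c(-c2cccs2)nc2n1CCS2` has not yet been measured. It stands to compound 3 as compound 2 stands to compound 1: thiophen-2-yl in place of 2,5-dimethylthiophen-3-yl on an aromatic carbon. This is the same kind of change, though the place is not identical. In compound 3 the carbon also lies two ring bonds from two ring atoms that each bear a fused ring.

Because the earlier step of a 1.6-fold lower number from compound 1 to compound 2 (0.20 log units; within the scatter) stayed within the scatter, the step of a 1.6-fold lower number from compound 3 to compound 4 (0.21 log units; within the scatter) is expected to be of similar, small size. Compound 4 is thus estimated at 9500 nM in this assay, with a range from 4000 nM to 25000 nM.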

Compound 4, concentration for 50% growth inhibition: 19500 nM
Compound 4: the middle estimate sits 2.1-fold (0.31 log units) below what was measured; the measured number falls inside the stated range.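

In this assay, replacing 2,5-dimethylthiophen-3-yl with thiophen-2-yl on the core of compound 3 gives a 1.3-fold higher number from compound 3 to compound 4 (0.10 log units; within the scatter), so this step, like the earlier one, stays small. Set side by side, the two steps do not differ, and the change reads the same on both cores as far as these data can tell: the same change on two cores in this assay, a 1.6-fold lower number (0.20 log units; within the scatter) from compound 1 to compound 2 and a 1.3-fold higher number (0.10 log units; within the scatter) from compound 3 to compound 4, 2.0-fold (0.30 log units) apart, within the scatter of two such steps. Going by these compounds alone, this shows only that the change has no readable effect on either of these two cores; both steps lie within the scatter, so their opposite signs carry no meaning, and the pair cannot show whether a larger effect would carry over from one core to another or whether the same would hold on any further core.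

The compounds shown leave open whether a different group on that aromatic carbon, such as a phenyl ring, an amine or a carboxylic acid, would shift the number on either core. They also leave open how far the thiophen-2-yl and 2,5-dimethylthiophen-3-yl groups matter compared with having no ring at that carbon at all.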